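This account rests on a few compounds, and the source may have more. Where it says the series, first, only, none or still open, it means among the compounds named here.

Measured so far:
compound 1 `CC/C(=C(\c1ccccc1)c1ccc(NC(=O)C(C)C)cc1)c1ccc(OCc2ccccc2)cc1` gives > 30000 nM
compound 2 `CC/C(=C(/c1ccccc1)c1ccc(NC(=O)C(C)C)cc1)c1ccccc1` gives > 30000 nM

In a functional assay on MCF7 cells (Homo sapiens) for inhibition, read by trypan blue exclusion, with a stated time of 72 h (on this read-out lower numbers stand for stronger inhibition of growth and higher numbers for weaker inhibition of growth), compound 2 gives only a limit of the assay, > 30000 nM, and not a number. Compound 1 also sits at a limit in this assay, > 30000 nM. Both results shown for this assay are limits, so compound 2 cannot be placed above or below any other compound; the only evidence is the limit of > 30000 nM in this assay, at which 2 of the 2 values shown sit.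

Compound 3 `CC/C(=C(/c1ccccc1)c1ccc(NC(=O)C(C)C)cc1)c1ccc(OCc2ccccc2)cc1` differs from compound 2 by benzyloxy in place of hydrogen on an aromatic carbon. No measured step of this kind exists among the compounds shown. Because both known values rest at the limit of > 30000 nM in this assay, at which 2 of the 2 values shown sit, the step from compound 2 to compound 3 in this assay is expected to be a step that the limit leaves unreadable from compound 2 to compound 3, none beyond the scatter. Compound 3 is expected to give about 35000 nM in this assay, estimated between 8000 nM and 150000 nM, most probably reported again as a limit.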

Compound 3, concentration for 50% growth inhibition: > 30000 nM
Compound 3: only a limit was reported (the forecaster's own chance of this, stated with the estimate: 70%); the middle value is on the limit's open side.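

In this assay compound 3 gives > 30000 nM, a limit and not a number. Within the data shown here, no step among compound 1, compound 2 and compound 3 can be read: the limit of > 30000 nM in this assay, at which 3 of the 3 values shown sit. The compounds shown leave open whether benzyloxy in place of hydrogen on an aromatic carbon, or the configuration of the double bond, affects growth inhibition at all.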